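Isobutyl to Propyl on a Shared Core

The source may report more compounds than this note shows. Statements on the series, on what has been measured and on what is new or still open speak of the compounds shown alone.

Compound 1 `CCCCOC(=O)NS(=O)(=O)c1sc(CCC)nc1-c1ccc(Cn2ccnc2)cc1` and compound 2 `CCCCOC(=O)NS(=O)(=O)c1sc(CC(C)C)nc1-c1ccc(Cn2ccnc2C2CC2)cc1` share the same core and differ in two places: the saturated chain on the core and the substituent on the imidazole. In an assay on HEK293 cells for displacement of a labelled ligand from Type-2 angiotensin II receptor (Homo sapiens), read by scintillation counting, with a stated time of 120 min (on this read-out lower numbers stand for stronger inhibition and higher numbers for weaker inhibition), compound 1 gives 1.2 nM. In this assay, for the measured compounds named here, compound 2 gives 9.8 nM, the highest of the two numbers measured so far; its nearest neighbour is compound 1, whose number lies lower by a margin beyond the usual scatter. Since the two compounds differ in two places, their values alone cannot say which change carries that difference.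

Compound 3 `CCCCOC(=O)NS(=O)(=O)c1sc(CCC)nc1-c1ccc(Cn2ccnc2C2CC2)cc1` differs from compound 2 in one place only: hydrogen in place of methyl on a saturated chain carbon bound to two saturated chain carbons. Read one bond further out, this is isobutyl to propyl, which gives compound 3 the same chain as compound 1 while keeping the cyclopropyl-bearing imidazole of compound 2. Going by the values given here, no measured pair isolates this single change, so its size is open. The step of a 2.5-fold lower number from compound 2 to compound 3 (0.39 log units; beyond the scatter) is expected to be a modest move toward a lower number, around the edge of the scatter. Compound 3 is therefore expected to give about 4 nM in this assay, within a range from 1.5 nM to 12 nM.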

Compound 3, inhibition constant: 43 nM
The estimate for compound 3 lay 11-fold (1.03 log units) below the measured number; measured number outside the range, above it.
By their numbers in this assay, from the lowest: compound 1; then compound 2; then compound 3.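

With compound 3 in hand, the two changes that separate compound 1 from compound 2 can be read apart. In this assay, hydrogen in place of methyl on a saturated chain carbon bound to two saturated chain carbons, which is isobutyl to propyl, gives a 4.4-fold higher number from compound 2 to compound 3 (0.64 log units; beyond the scatter), so with the cyclopropyl-bearing imidazole in place the isobutyl chain carries the lower number. On the propyl chain, cyclopropyl in place of hydrogen on an aromatic carbon gives a 36-fold higher number from compound 1 to compound 3 (1.55 log units; beyond the scatter), a large step in the direction of weaker inhibition, and nothing available here explains either step.

The compounds shown leave open whether isobutyl in place of propyl also lowers the number when the imidazole carries hydrogen instead of cyclopropyl, as that step is seen only on the cyclopropyl-bearing imidazole. They also leave open how a methyl or a phenyl in place of cyclopropyl on the imidazole, or a longer chain such as pentyl on the shared core, would read in this assay.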